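This account rests on a few compounds, and the source may have more. Where it says the series, first, only, none or still open, it means among the compounds named here.

Series notes, a functional assay on CCRF-CEM cells (Homo sapiens) for inhibition; a lower number here means a stronger inhibitor, a higher number a weaker inhibitor.

Compound 1 `O=C1/C(=C/c2ccc(Cl)cc2)Cc2ccccc21` gives 284000 nM in this assay. Compound 2 `O=C1/C(=C/c2ccc(Br)cc2)Cc2ccccc21` carries the change bromo in place of chloro on an aromatic carbon and gives 284000 nM; the step of no change at the digits printed from compound 1 to compound 2 (within the scatter) is flat. Compound 3 `O=C1/C(=C/c2cccc(Cl)c2)CCCc2ccccc21` is built on another core; how the two cores differ is not broken down here. Compound 3 gives 9440 nM in this assay, the lowest of the three numbers, and its gap to compound 1 and to compound 2 lies beyond the scatter in both cases.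

Compound 4 `O=C1/C(=C/c2cccc(Br)c2)CCCc2ccccc21`, not yet measured in this assay, differs from compound 3 by bromo in place of chloro on an aromatic carbon. For the measured compounds named here, this is the same kind of change as the one from compound 1 to compound 2, though not the same: in compound 1 the exchanged group sits para to a large group, in compound 3 it sits meta to a large group. The change occurs twice among the compounds shown, once with a measured outcome.

Expectation: bromo in place of chloro on an aromatic carbon left the number unchanged where it was measured. Because no change at the digits printed from compound 1 to compound 2 (within the scatter) was flat, compound 4 is expected to show a step of no change at the digits printed from compound 3 to compound 4 (within the scatter). Going by the values given here, the single precedent sits on another core and at another place, so the estimate is given the usual width of repeated measurements. Compound 4 is expected to give about 9440 nM in this assay, with a range from 4700 nM to 19000 nM.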

Compound 4, half-maximal inhibitory concentration: 8900 nM
Compound 4: the middle estimate sits 1.1-fold (0.03 log units) above what was measured, within the range that was stated.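

In this assay the exchange of chloro for bromo on the shared aromatic ring gives a 1.1-fold lower number from compound 3 to compound 4 (0.03 log units; within the scatter), and this agrees with the earlier step on the other core: the same change on two cores in this assay, no change at the digits printed (within the scatter) from compound 1 to compound 2 and a 1.1-fold lower number (0.03 log units; within the scatter) from compound 3 to compound 4, 1.1-fold (0.03 log units) apart, within the scatter of two such steps.

Within these two pairs the exchange therefore carries from one core to the other without a visible effect, both where compound 1 stands at 284000 nM and where compound 3 stands at 9440 nM. It does not show that the result holds beyond these two pairs, and since the exchanged group sits meta to a large group in compound 3 but elsewhere in compound 1, core and place change together and their contributions cannot be separated.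

The compounds shown leave open whether groups other than these two halogens, such as fluoro, methoxy, an amine or a carboxylic acid, would also leave the number flat at the same place on the ring. For the compounds shown here, they also leave open how much of the difference between the two pairs belongs to the core and how much to the place of the halogen, since no pair of compounds differing only in one of these two features stands among them.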